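The compounds below may be only part of what the source reports. "The series", "measured", "known", "first", "only" and "open" are said of these compounds alone.

Series in a functional assay on M21 cells (Homo sapiens) for antiproliferative activity, read by sulforhodamine B assay, with a stated time of 48 h; on this read-out lower numbers stand for stronger inhibition and higher numbers for weaker inhibition:
compound 1 `Cc1ccccc1OS(=O)(=O)c1ccc(N2CCN(C)C2=O)cc1`: 2900 nM
compound 2 `COc1ccccc1OS(=O)(=O)c1ccc(N2CCN(C)C2=O)cc1`: 21000 nM
compound 3 `CN1CCN(c2ccc(S(=O)(=O)Oc3cccc(I)c3)cc2)C1=O`: 400 nM

Compound 3 has the lowest number of the three, and both of its gaps lie beyond the scatter: a 7.3-fold lower number from compound 1 to compound 3 (0.86 log units; beyond the scatter) is modest and a 53-fold lower number from compound 2 to compound 3 (1.72 log units; beyond the scatter) is large. The next change leads to compound 4 `CN1CCN(c2ccc(S(=O)(=O)Oc3ccc(F)cc3)cc2)C1=O`: 4-fluorophenyl in place of 3-iodophenyl on an oxygen. In words, this is 4-fluorophenyl in place of 3-iodophenyl on an oxygen.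

The two steps into compound 3 change the same group on that oxygen, so they bear most directly on this change. Read in reverse, each would take the number up on leaving 3-iodophenyl. A further step, a 7.2-fold higher number from compound 1 to compound 2 (0.86 log units; beyond the scatter), shows that a small swap on this group can also move the number beyond the scatter. Within the data shown here, no measured compound carries 4-fluorophenyl, and with only three compounds the evidence is thin. A modest step to a higher number is therefore expected in this assay, closer in size to a 7.3-fold lower number from compound 1 to compound 3 (0.86 log units; beyond the scatter) than to a 53-fold lower number from compound 2 to compound 3 (1.72 log units; beyond the scatter). The estimated step is a 6.3-fold higher number from compound 3 to compound 4 (0.80 log units; beyond the scatter). For compound 4 the estimated value is 2500 nM, with an expected range of 700 nM to 9000 nM.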

Compound 4, half-maximal inhibitory concentration: > 100000 nM
Compound 4: only a limit was reported (the forecaster's own chance of this, stated with the estimate: 5%); middle value at least 40-fold (1.60 log units) from the limit.
By their numbers in this assay, from the lowest: compound 3; then compound 1; then compound 2. At a limit, above all of these: compound 4.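

In this assay, compound 4 is recorded only as a limit of the assay, not as a number: the limit of > 100000 nM in this assay, at which 1 of the 4 values shown sits.

The aryl group on this oxygen sets the number over a wider span than the first three compounds showed, with an at least 250-fold higher number from compound 3 to compound 4 (2.39 log units; beyond the scatter) as the largest step in the series, and both remaining steps also lying beyond the scatter: an at least 34-fold higher number from compound 1 to compound 4 (1.53 log units; beyond the scatter) and an at least 4.7-fold higher number from compound 2 to compound 4 (0.67 log units; beyond the scatter). The 3-iodophenyl and 4-fluorophenyl groups match in heavy-atom count, in their carbon-only aromatic ring and in their lack of hydrogen-bond donors and acceptors, so a change that leaves all of these counts the same can still separate the lowest number in the series from the limit.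

This change swaps iodine for fluorine and also moves the halogen, and the compounds shown leave open which of the two matters; 3-fluorophenyl and 4-iodophenyl on the same oxygen would separate them. Also open, going by these compounds, are the true size of the steps into compound 4, as each rests on a limit, and how a 3-aminophenyl or 3-carboxyphenyl group would read at this position.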